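This account rests on a few compounds, and the source may have more. Where it says the series, first, only, none or still open, it means among the compounds named here.

Working notes on the series. Within the data shown here, the three compounds measured so far all carry the shared core and differ in the amine side chain and in the aryl group. In a functional assay for agonist activity at G protein-coupled receptor 88 (Homo sapiens), read by HTRF and cAMP accumulation (a lower number here means that less compound is needed, a higher number that more compound is needed for the effect), compound 1 `O=C([C@@H]1C[C@H]1c1ccccc1)N(CCNCC1CCCC1)c1ccc(-c2ccccc2)cc1` gives 2.5 nM, compound 2 `CC(C)C[C@H](N)CN(C(=O)[C@@H]1C[C@H]1c1ccccc1)c1ccc(-c2cccs2)cc1` gives 1500 nM, and compound 3 `CC[C@H](C)[C@H](N)CN(C(=O)[C@@H]1C[C@H]1c1ccccc1)c1ccc(-c2ccc(C(C)(C)C)cc2)cc1` gives 750 nM. Compound 3 thus stands second highest of the three numbers in this assay: its nearest neighbour is compound 2, whose value lies within the scatter of that of compound 3, while compound 1 stands far lower, beyond the scatter. Among the measured compounds shown here, no pair among the measured compounds differs in only one place, so nothing can be read off about a single change on this aryl position.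

Compound 4 `CC[C@H](C)[C@H](N)CN(C(=O)[C@@H]1C[C@H]1c1ccccc1)c1ccc(-c2ccc(NC(C)=O)cc2)cc1` is not yet measured. It differs from compound 3 as follows (acetamido in place of tert-butyl on an aromatic carbon). The data hold no comparable change on the aryl group for a measured pair, so the expectation rests only on the position of compound 3 at 750 nM in this assay and on the size of the group exchanged. The step from compound 3 to compound 4 in this assay is expected to be small, a 1.3-fold higher number from compound 3 to compound 4 (0.12 log units; within the scatter), likely not beyond the scatter. For compound 4 in this assay the estimate is 1000 nM, with a range from 250 nM to 4000 nM.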

Compound 4, half-maximal effective concentration: 5500 nM
Estimate against measurement, compound 4: 5.5-fold (0.74 log units) below, outside the stated range (above it).
By their numbers in this assay, from the lowest: compound 1; then compounds 3 and 2 (each within the scatter of the next); then compound 4.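

In this assay, among these compounds, acetamido in place of tert-butyl on the aromatic carbon, para to a large group, gives a 7.3-fold higher number from compound 3 to compound 4 (0.87 log units; beyond the scatter), the first change that can be read at a single place. This shows that the position does not tolerate every group of this size: the two groups count the same number of heavy atoms, yet the exchange, which replaces an all-carbon group with one holding nitrogen and oxygen and adds one hydrogen-bond donor and one hydrogen-bond acceptor, is accompanied by a step beyond the scatter. No measurement at hand accounts for this step, so it cannot be assigned to any one feature of the acetamido group.

The compounds shown leave open whether the higher number follows the amide hydrogen, the carbonyl or the loss of the branched carbon chain, which a methoxy group, an amine, a carboxylic acid or an isopropyl group at this position, on the same side chain, could help to separate. Also open, from the compounds shown here alone, is whether the same exchange would give a step of similar size on the side chain of compound 1, which stands at 2.5 nM.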